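Swapping carboxymethyl for 1H-tetrazol-5-yl on the shared core

A few compounds are considered here, and "the series" means these few. Any claim that something is new, unique, unknown or untested is made for them only; others in the source may bear on it.

In an ADME assay on MDCKII-LE cells (Canis lupus familiaris) for permeability (on this read-out lower numbers stand for lower permeability and higher numbers for higher permeability), compound 1 (`O=C(O)c1ccc(NC(=O)[C@H](CC2CCCC2)n2cnc(C(F)(F)F)c2)nc1`) gives 1 10^-6 cm/s and compound 2 (`O=C(O)Cc1ccc(NC(=O)[C@H](CC2CCCC2)n2cnc(C(F)(F)F)c2)nc1`) gives 0.4 10^-6 cm/s as the lower of the two numbers. Compound 3 (`O=C(Nc1ccc(-c2nnn[nH]2)cn1)[C@H](CC1CCCC1)n1cnc(C(F)(F)F)c1`) is still unmeasured and differs from compound 2 by one change (1H-tetrazol-5-yl in place of carboxymethyl on an aromatic carbon): 1H-tetrazol-5-yl in place of carboxymethyl on an aromatic carbon. For the measured compounds named here, the only measured step at this place is modest (a 2.5-fold lower number from compound 1 to compound 2 (0.40 log units; beyond the scatter)) and involves other groups, so it guides only loosely. No clear step beyond the usual scatter is therefore expected in this assay (a 1.3-fold higher number from compound 2 to compound 3 (0.10 log units; within the scatter)). For compound 3 the estimated value is 0.5 10^-6 cm/s with an expected range from 0.15 10^-6 cm/s to 1.5 10^-6 cm/s around it.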

Compound 3, apparent permeability: 0.6 10^-6 cm/s
Beside the measured number, compound 3's estimate is 1.2-fold (0.08 log units) below it, and the stated range covers the measured number.
By their numbers in this assay, from the lowest: compounds 2, 3 and 1 (each within the scatter of the next, the first and the last beyond it).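

In this assay putting 1H-tetrazol-5-yl in place of carboxymethyl gives a 1.5-fold higher number from compound 2 to compound 3 (0.18 log units; within the scatter) and putting it in place of carboxy gives a 1.7-fold lower number from compound 1 to compound 3 (0.22 log units; within the scatter) on the same aromatic carbon. A five-membered aromatic ring with 4 hetero atoms can therefore stand at this place with neither step going beyond the scatter, something the two earlier compounds could not show. Nothing measured here explains these numbers. The compounds shown leave open how a methyl ester or an amine would read at this place. They also leave open whether a longer chain carrying the carboxylic acid would lower the number further.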